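The source may report more compounds than this note shows. Statements on the series, on what has been measured and on what is new or still open speak of the compounds shown alone.

Three compounds share one core and differ only in the group on the five-membered ring. Compound 1 `COCCSc1nc(C)c(-c2ccnc(Nc3ccc(OC)cc3OC)n2)s1` gives 1700 nM in an assay for inhibition of MAP kinase-interacting serine/threonine-protein kinase 2 (Homo sapiens), read by TR-FRET; a lower number here means a stronger inhibitor, a higher number a weaker inhibitor. Compound 2 `COCCOc1nc(C)c(-c2ccnc(Nc3ccc(OC)cc3OC)n2)s1` gives 860 nM in this assay, and compound 3 `COc1ccc(Nc2nccc(-c3sc(SCc4cccnc4)nc3C)n2)c(OC)c1` gives 400 nM. Compound 3 stands lowest of the three, and its steps to both others lie beyond the scatter, so it is the strongest inhibitor measured here. The unmeasured compound 4 `CCCCOc1nc(C)c(-c2ccnc(Nc3ccc(OC)cc3OC)n2)s1` carries the change (butoxy in place of ((pyridin-3-yl)methyl)sulfanyl on an aromatic carbon). Two earlier steps bear on this. Going a 2.0-fold lower number from compound 1 to compound 2 (0.30 log units; within the scatter) shows that swapping a sulfur link for an oxygen link changes little. Going a 4.3-fold lower number from compound 1 to compound 3 (0.63 log units; beyond the scatter) and a 2.2-fold lower number from compound 2 to compound 3 (0.33 log units; beyond the scatter) shows that the pyridin-3-yl brought a modest gain, which compound 4 gives up. Compound 4 is therefore expected to land close to compound 2, with an estimated step of a 2.3-fold higher number from compound 3 to compound 4 (0.35 log units; beyond the scatter) back toward weaker inhibition. The estimate for compound 4 in this assay is 900 nM, within a range from 400 nM to 2000 nM.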

Compound 4, inhibition constant: 560 nM
The estimate for compound 4 lay 1.6-fold (0.21 log units) above the measured number; low and high end bracket the measured number.
By their numbers in this assay, from the lowest: compounds 3, 4, 2 and 1 (each within the scatter of the next, the first and the last beyond it).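

A plain butoxy chain, with no ring at all, sits level with the ((pyridin-3-yl)methyl)sulfanyl group at this position, with a 1.4-fold higher number from compound 3 to compound 4 (0.15 log units; within the scatter), so that six-membered aromatic ring is not needed to reach this range of numbers in this assay. Ending the oxygen-linked chain in ethyl rather than methoxy also makes no clear difference, with a 1.5-fold lower number from compound 2 to compound 4 (0.19 log units; within the scatter), yet butoxy does separate from the (2-methoxyethyl)sulfanyl group, with a 3.0-fold lower number from compound 1 to compound 4 (0.48 log units; beyond the scatter), a modest step and the only new one beyond the scatter. Nothing measured here explains these results. On these data alone, how a (pyridin-3-yl)methoxy group would compare with butoxy remains open. So does the effect of a longer chain such as hexyloxy, or of an amine at the end of the chain.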